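The source may report more compounds than this note shows. Statements on the series, on what has been measured and on what is new or still open speak of the compounds shown alone.

Measured so far:
Compound 1 `Cn1c(N)c(-c2nc3ccccc3[nH]2)c2nc(C#N)c(C#N)nc21`: > 50000 nM (a limit)
Compound 2 `CN(C)CCCn1c(N)c(-c2nc3ccccc3[nH]2)c2nc(C#N)c(C#N)nc21`: 2390 nM

Going by the values given here, in a functional assay on HL60/MX2 cells (Homo sapiens) for antiproliferative activity, read by MTT assay, with a stated time of 48 h (a lower number here means a stronger inhibitor, a higher number a weaker inhibitor), compound 2 gives 2390 nM, the only actual number available so far. Compound 1 stands at > 50000 nM, and this is a limit of the assay, not a number. The one other entry in the series is thus (the limit of > 50000 nM in this assay, at which 1 of the 2 values shown sits).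

Compound 3 `CN(C)CCCn1c(N)c(-c2nc3ccccc3s2)c2nc(C#N)c(C#N)nc21` keeps the 3-(dimethylamino)propyl group of compound 2 and changes the other substituent on the five-membered aromatic ring: 1,3-benzothiazol-2-yl replaces 1H-benzimidazol-2-yl on an aromatic carbon, next to the ring atom that bears an amino group. 1,3-benzothiazol-2-yl in place of 1H-benzimidazol-2-yl on an aromatic carbon

Among the compounds with values here, the only measured step, an at least 20-fold lower number from compound 1 to compound 2 (1.32 log units; beyond the scatter), is large, but it concerns the group that compound 3 retains. Within the data shown here, no measured step touches the place that changes now, so the data give no direction for the change in this assay. The expected change is therefore small, with a wide margin on either side: a 1.2-fold higher number from compound 2 to compound 3 (0.07 log units; within the scatter). For compound 3 the estimated value is 2800 nM, with an expected range from 700 nM to 12000 nM.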

Compound 3, half-maximal inhibitory concentration: 1310 nM
Beside the measured number, compound 3's estimate is 2.1-fold (0.33 log units) above it; low and high end bracket the measured number.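

In this assay the place on the aromatic carbon next to the ring atom that bears an amino group now has a measured step of its own: 1,3-benzothiazol-2-yl in place of 1H-benzimidazol-2-yl gives a 1.8-fold lower number from compound 2 to compound 3 (0.26 log units; within the scatter) and so does not separate the two compounds. The entering group has 0 hydrogen-bond donors against 1 in the group that leaves, so with the 3-(dimethylamino)propyl group kept, that donor is not needed for a value in this range in this pair. No measured property shown bears on this result.

Going by these compounds, it remains open whether a 1,3-benzoxazol-2-yl or a plain phenyl group at this place would also keep the value in this range, since one exchange between two related groups says little about the place as a whole. Also open, on these data alone, is how 1,3-benzothiazol-2-yl behaves with other groups on the ring nitrogen, such as the methyl of compound 1 or a longer chain ending in a morpholine.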